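Piperidin-1-yl for ethyl(4-fluorobenzyl)amino: second occurrence

The source may report more compounds than this note shows. Statements on the series, on what has been measured and on what is new or still open speak of the compounds shown alone.

In an assay on HEK293 cells for inhibition of Steryl-sulfatase (Homo sapiens), tested at 0.1 uM (a lower number here means a weaker effect, a higher number a stronger effect of the compound at the concentration tested), compound 2 `CCN(Cc1ccc(F)cc1)c1ccc(C(=O)N2CCc3ccc(OS(N)(=O)=O)cc3C2)cc1` gives 69.1%. Compound 1 `NS(=O)(=O)Oc1ccc2c(c1)CN(C(=O)c1ccc(N3CCCCC3)cc1)CC2` gives 11.5%, the step of a number 57.6 percentage points lower from compound 2 to compound 1 (beyond the scatter) arising from piperidin-1-yl in place of ethyl(4-fluorobenzyl)amino on an aromatic carbon. Compound 3 `CCN(Cc1ccc(F)cc1)c1cccc(C(=O)N2CCc3ccc(OS(N)(=O)=O)cc3C2)c1` has the same atoms as compound 2 joined differently; the difference between the two cores is not broken down here. In this assay compound 3 gives 10.9%, which lies within the scatter of the value of compound 1 and far from that of compound 2.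

Compound 4 `NS(=O)(=O)Oc1ccc2c(c1)CN(C(=O)c1cccc(N3CCCCC3)c1)CC2` is not yet measured. It arises from compound 3 by piperidin-1-yl in place of ethyl(4-fluorobenzyl)amino on an aromatic carbon, the same kind of change as from compound 2 to compound 1, though the place differs: para to a large group there, meta to a large group here. The earlier step was large and downward, but compound 3 already sits near the floor of the read-out, so a drop of that size cannot repeat. The step from compound 3 to compound 4 is expected to be a number 2.9 percentage points lower from compound 3 to compound 4 (within the scatter), because compound 3 starts at 10.9%. For compound 4 in this assay an estimated 8% is expected, most likely between 0% and 20%.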

Compound 4, a percentage reported as inhibition, at one concentration (the size of the read-out at that concentration, not a potency): 1%
The estimate for compound 4 lay 7 percentage points above the measured number; the measured number falls inside the stated range.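

The change gives a number 9.9 percentage points lower from compound 3 to compound 4 (within the scatter) in this assay on this core, so here piperidin-1-yl in place of ethyl(4-fluorobenzyl)amino has no effect that can be told from the scatter. The size of the step does not carry from one core to the other: the same change on two cores in this assay, a number 57.6 percentage points lower (beyond the scatter) from compound 2 to compound 1 and a number 9.9 percentage points lower (within the scatter) from compound 3 to compound 4, 47.7 percentage points apart, beyond the scatter of two such steps. Within the data shown here, this does not show that the two cores respond differently in any deeper sense, as compound 3 starts at 10.9% and leaves little room for a further fall, and a read-out at one concentration gives no potency for either compound.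

Open, going by these compounds, is which part of ethyl(4-fluorobenzyl)amino carries the higher read-out of compound 2, which a benzyl group without fluorine, a morpholine or a longer chain on the amine nitrogen could separate. Also open, on these data alone, is whether any such group, placed meta to a large group, lifts the read-out on the core of compound 3.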